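The compounds below may be only part of what the source reports. "The series", "measured", "known", "first", "only" and "open" are said of these compounds alone.

Measured compounds:
compound 1 `CCC1C(=O)N(C)c2cnc(-n3ccc4cc(C(=O)NC)ccc43)nc2N1c1ccn(C)n1` — 35700 nM
compound 2 `CC[C@@H]1C(=O)N(C)c2cnc(-n3ccc4cc(C(=O)NC(C)C)ccc43)nc2N1C1CCCC1` — 1840 nM
compound 3 `CCCNC(=O)c1ccc2c(ccn2-c2ncc3c(n2)N(C2CCCC2)[C@H](CC)C(=O)N3C)c1` — 786 nM

In a functional assay on NCI-H1975 cells (Homo sapiens) for antiproliferative activity, read by CCK-8 assay, with a stated time of 72 h (a lower number here means a stronger inhibitor of growth, a higher number a weaker inhibitor of growth), compound 1 gives the highest of the three numbers. Compound 2 stands a long way lower at 1840 nM, and compound 3 lower still at 786 nM; both differ from compound 1 in more than one place, so their gap to compound 1 cannot be tied to a single change. Among the measured compounds shown here, the one single-point step among the measured compounds is a 2.3-fold lower number from compound 2 to compound 3 (0.37 log units; beyond the scatter), a modest shift that comes from enlarging the group on the amide-type nitrogen.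

Compound 4 `CCC1C(=O)N(C)c2cnc(-n3ccc4cc(C(=O)NC5CCCC5)ccc43)nc2N1c1ccn(C)n1` carries the same core as compound 1, but with cyclopentyl in place of methyl on an amide-type nitrogen. The step from compound 2 to compound 3 bears on it only loosely, since cyclopentyl is a much larger change than propyl for isopropyl, and the amide-type nitrogen in compound 4 sits in the setting of compound 1 rather than that of compounds 2 and 3. The larger amide substituents of compounds 2 and 3 go with lower numbers, but other changes travel with them. Compound 4 is therefore expected to show a moderate step downward, a 3.6-fold lower number from compound 1 to compound 4 (0.55 log units; beyond the scatter), with the direction more secure than the size. Compound 4 is estimated at 10000 nM, within 3000 nM to 30000 nM.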

Compound 4, concentration for 50% growth inhibition: "not active" (no number reported)
No number was reported for compound 4; there is nothing to compare the estimate with.
By their numbers in this assay, from the lowest: compound 3; then compound 2; then compound 1.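

In this assay, among the compounds shown here, compound 4 is reported as "not active" with no number, so no step from compound 1 to compound 4 can be read. No measured evidence bears on this result. The compounds shown leave open how far cyclopentyl in place of methyl on the amide-type nitrogen shifts growth inhibition on the core of compound 1.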